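The source may report more compounds than this note shows. Statements on the series, on what has been measured and on what is new or still open speak of the compounds shown alone.

Measured so far:
compound 1 `CCCNc1ccc(NC(=O)c2cc(Cl)ccc2O)c(Cl)c1` — 22500 nM
compound 2 `CN(C)c1ccc(NC(=O)c2cc(Cl)ccc2O)c(Cl)c1` — 85100 nM
compound 3 `O=C(Nc1ccc(N(CC2CC2)CC2CC2)cc1Cl)c1cc(Cl)ccc1O` — 12800 nM

In an ADME assay on A549 cells (Homo sapiens) for cytotoxicity, read by resazurin assay, with a stated time of 48 h (on this read-out lower numbers stand for higher toxicity in this test and higher numbers for lower toxicity in this test), compound 1 stands second highest of the three numbers; its nearest neighbour is compound 3 by a 1.8-fold lower number from compound 1 to compound 3 (0.24 log units; within the scatter), while compound 2 lies further off by a 3.8-fold higher number from compound 1 to compound 2 (0.58 log units; beyond the scatter). Compound 4 `O=C(Nc1ccc(NCc2ccccc2)cc1Cl)c1cc(Cl)ccc1O` has not yet been measured. It differs from compound 1 by phenyl in place of ethyl on a saturated chain carbon bound to a nitrogen on an aromatic ring.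

Among the measured compounds shown here, two measured steps bear on this change, both at the nitrogen on the aromatic ring. Going to the smaller dimethylamino group gave a 3.8-fold higher number from compound 1 to compound 2 (0.58 log units; beyond the scatter), whereas going to the larger bis(cyclopropylmethyl)amino group gave a 1.8-fold lower number from compound 1 to compound 3 (0.24 log units; within the scatter), and between those two extremes the step was a 6.6-fold lower number from compound 2 to compound 3 (0.82 log units; beyond the scatter). Larger groups on that nitrogen have thus gone with lower numbers, though only compound 3 supports this on the lower side. Since benzylamino carries more heavy atoms than propylamino, a small downward step in this assay is expected for compound 4, which is estimated at a 1.5-fold lower number from compound 1 to compound 4 (0.18 log units; within the scatter), not clearly beyond the scatter. Compound 4 is therefore expected to give 15000 nM, with a range from 6000 nM to 40000 nM.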

Compound 4, half-maximal cytotoxic concentration: 19700 nM
Compound 4: middle estimate off by 1.3-fold (0.12 log units), on the low side, within the range that was stated.
By their numbers in this assay, from the lowest: compounds 3, 4 and 1 (each within the scatter of the next); then compound 2.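

In this assay, phenyl in place of ethyl on a saturated chain carbon bound to a nitrogen on an aromatic ring gave a 1.1-fold lower number from compound 1 to compound 4 (0.06 log units; within the scatter), so this place accepts an aromatic ring with no change that can be told apart from the propylamino compound. Compound 4 also lies close to the bis(cyclopropylmethyl)amino compound (a 1.5-fold higher number from compound 3 to compound 4 (0.19 log units; within the scatter)), but clearly apart from the dimethylamino compound (a 4.3-fold lower number from compound 2 to compound 4 (0.64 log units; beyond the scatter)). Among these four, then, compound 2 alone stands apart, while compounds 1, 3 and 4 cannot be separated, despite their different groups on the nitrogen; no measurement shown accounts for this.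

On these data alone, it remains open whether a longer chain such as phenylethyl would stay at this level. The same holds for a benzyl group carrying a carboxylic acid or an amine on its ring.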